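This account rests on a few compounds, and the source may have more. Where it says the series, first, only, none or still open, it means among the compounds named here.

Measured so far in a functional assay, with a stated time of 90 s; on this read-out lower numbers stand for stronger inhibition and higher numbers for weaker inhibition:
- compound 1, `Cc1ccc(-c2c3ccc4ccccc4c3nc3c2c(C)nc2c4ccccc4ccc32)cc1`: 192 ug/mL
- compound 2, `Cc1nc2c3ccccc3ccc2c2nc3c(ccc4ccccc43)c(C)c12`: 195 ug/mL
- compound 3, `Cc1nc2c3ccccc3ccc2c2nc3c(ccc4ccccc43)c(-c3ccccc3)c12`: 188 ug/mL

Compound 3 gives the lowest of these three numbers, but the steps of a 1.0-fold lower number from compound 1 to compound 3 (0.01 log units; within the scatter) and a 1.0-fold lower number from compound 2 to compound 3 (0.02 log units; within the scatter) both lie within the scatter, so none of the three can be called the most active. Compound 4, `Cc1nc2c3ccccc3ccc2c2nc3c(ccc4ccccc43)c(-c3cccnc3)c12`, differs from compound 3 in one place: pyridin-3-yl in place of phenyl on an aromatic carbon. For the measured compounds named here, no measured step swaps phenyl for pyridin-3-yl. What is known is that three exchanges at this same place, a 1.0-fold higher number from compound 1 to compound 2 (0.01 log units; within the scatter), a 1.0-fold lower number from compound 1 to compound 3 (0.01 log units; within the scatter) and a 1.0-fold lower number from compound 2 to compound 3 (0.02 log units; within the scatter), all stayed within the scatter. On that basis no step beyond the scatter is expected for compound 4, which would mean a 1.0-fold higher number from compound 3 to compound 4 (0.00 log units; within the scatter). Compound 4 is therefore estimated at 190 ug/mL, within a range of 110 ug/mL to 330 ug/mL.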

Compound 4, half-maximal inhibitory concentration: 156 ug/mL
The estimate for compound 4 lay 1.2-fold (0.09 log units) above the measured number, within the range that was stated.
By their numbers in this assay, from the lowest: compounds 4, 3, 1 and 2 (each within the scatter of the next).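

Swapping phenyl for pyridin-3-yl, which brings a ring nitrogen and one hydrogen-bond acceptor to the place opposite the ring nitrogen of the shared core, gives a 1.2-fold lower number from compound 3 to compound 4 (0.08 log units; within the scatter) in this assay and so leaves the read-out essentially unmoved. Comparison with the other two groups at this place gives a 1.3-fold lower number from compound 2 to compound 4 (0.10 log units; within the scatter) and a 1.2-fold lower number from compound 1 to compound 4 (0.09 log units; within the scatter) as well, so a heteroaromatic ring here behaves like methyl, phenyl and 4-methylphenyl. No supporting measurement bears on these small steps. Going by these compounds, whether an amine, a carboxylic acid or a longer chain at this place would produce a step beyond the scatter remains open.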